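Cyclohexyl to 2-methoxyethyl at the ester oxygen

This account rests on a few compounds, and the source may have more. Where it says the series, first, only, none or still open, it means among the compounds named here.

Of the compounds shown here, three sharing one core have been tested in a functional assay (cardiac atrium) for agonist activity, with Cavia porcellus as the target; a higher number here means that more compound is needed for the effect, a lower number that less compound is needed. Compound 1 `CC1=NC(C)=C([N+](=O)[O-])C(c2cccnc2)/C1=C(\O)OC1CCCCC1` gives 2760 nM. Compound 2 `CC1=NC(C)=C([N+](=O)[O-])C(c2ccncc2)/C1=C(\O)OC1CCCCC1` gives 4940 nM, and the step of a 1.8-fold higher number from compound 1 to compound 2 (0.25 log units; within the scatter) stays within the scatter of repeated measurements, so the two numbers are not told apart. Compound 3 `CC1=NC(C)=C([N+](=O)[O-])C(c2ccccn2)/C1=C(\O)OC1CCCCC1` gives 3700 nM; 8450 nM (2 entries), and the spread between its two entries, (the several entries of compound 3 in this assay, 3700 nM; 8450 nM (2 entries)), shows how far repeats of this assay can move. Among the single numbers, compound 2 carries the higher one, with compound 1 its only neighbour.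

Compound 4 `COCCO/C(O)=C1\C(C)=NC(C)=C([N+](=O)[O-])C1c1ccncc1` differs from compound 2 in one place: 2-methoxyethyl in place of cyclohexyl on an oxygen on an unsaturated carbon. Among the measured compounds shown here, no measured step among compounds 1, 2 and 3 touches this part of the molecule; all of them vary only the pyridyl ring. The expectation for compound 4 in this assay therefore rests on compound 2 alone, with a wide range and no direction that the measured steps support. Compound 4 is estimated at 6000 nM, between 1500 nM and 25000 nM, which means an expected step of a 1.2-fold higher number from compound 2 to compound 4 (0.08 log units; within the scatter).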

Compound 4, half-maximal effective concentration: 37700 nM
Compound 4: the middle estimate sits 6.3-fold (0.80 log units) below what was measured, outside the stated range (above it).
By their numbers in this assay, from the lowest: compounds 1 and 2 (each within the scatter of the next); then compound 4.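

Replacing cyclohexyl with 2-methoxyethyl on an oxygen on an unsaturated carbon gives the only step among the compounds shown that lies beyond the scatter in this assay: a 7.6-fold higher number from compound 2 to compound 4 (0.88 log units; beyond the scatter). The one listed pyridyl step does not separate its two compounds, so this position shows a readable sensitivity to the group it carries that the earlier comparison did not. The step is also wider than the spread between repeat entries in this assay: the several entries of compound 3 in this assay, 3700 nM; 8450 nM (2 entries)

With a single replacement shown here, it remains open whether the higher number follows from the departure of the carbon ring or the entry of the chain with its oxygen, a question that an open hexyl chain of carbon only or a tetrahydropyranyl ring could help to separate. On these data alone, it also remains open whether the same replacement would have a similar effect with pyridin-3-yl in place of pyridin-4-yl.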